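Swapping a Furan for a Methylsulfonylphenyl: Cytotoxicity Outlook

The source may report more compounds than this note shows. Statements on the series, on what has been measured and on what is new or still open speak of the compounds shown alone.

Of the compounds shown here, three sharing one core have been tested in an ADME assay on BJ cells (Homo sapiens) for cytotoxicity, read by CellTiter-Glo and resazurin assay, with a stated time of 72 h (a higher number here means that more compound is needed for the effect, a lower number that less compound is needed), so far. Compound 1 `CC(=O)Nc1cccc(-c2ccc(C(=O)N(Cc3cccc(OCCCCCC(=O)O)c3)C(C)C)cc2)c1` reaches only a limit of the assay there, namely > 26000 nM. Compound 2 `CC(C)N(Cc1cccc(OCCCCCC(=O)O)c1)C(=O)c1ccc(-c2ccncc2)cc1` likewise stops at the assay limit, > 26000 nM. Compound 3 `CC(C)N(Cc1cccc(OCCCCCC(=O)O)c1)C(=O)c1ccc(-c2ccco2)cc1` also gives only a limit of the assay, > 26000 nM. Because (the limit of > 26000 nM in this assay, at which 3 of the 3 values shown sit), none of the three shows a measurable effect on the cells, and the differences between them cannot be read: a step that the two limits leave unreadable from compound 1 to compound 2, a step that the two limits leave unreadable from compound 1 to compound 3 and a step that the two limits leave unreadable from compound 2 to compound 3 all remain without a readable size or direction. Compound 3 therefore stands among values that are all limits, with nothing to rank against.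

The next compound, compound 4 `CC(C)N(Cc1cccc(OCCCCCC(=O)O)c1)C(=O)c1ccc(-c2cccc(S(C)(=O)=O)c2)cc1`, differs from compound 3 in one place: 3-(methylsulfonyl)phenyl in place of furan-2-yl on an aromatic carbon. The measured steps that bear on this change are the three unreadable steps just named, as each of them also exchanges the group at this same position; they offer no size and no direction to build on. With every measured compound sitting at the limit, the expectation is that compound 4 also shows no effect within the tested range, estimated around 40000 nM, between 20000 nM and 100000 nM. The step this estimate implies, a step that the limit leaves unreadable from compound 3 to compound 4, is expected to be no change beyond the scatter.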

Compound 4, half-maximal effective concentration: > 26000 nM
Compound 4 gave a limit, no number; the forecaster's own chance of this, stated with the estimate: 85%; the middle value is on the limit's open side.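

The steps linking compound 4 to compound 1, compound 2 and compound 3 cannot be read, because each value is a limit of the assay rather than a number: the limit of > 26000 nM in this assay, at which 4 of the 4 values shown sit. Still open, from the compounds shown here alone, is how much of each compound would produce an effect on these cells, and whether exchanging the group on the aromatic carbon changes that amount.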